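A few compounds are considered here, and "the series" means these few. Any claim that something is new, unique, unknown or untested is made for them only; others in the source may bear on it.

Measured compounds:
compound 1, `COC[C@@H]1CCCN1C(=O)C1CCCN1c1cc(Nc2cccc(Br)c2)ncn1`, 0%
compound 2, `Cc1cccc(N(C)c2cc(Nc3cccc(C(=O)N4CCCC5CCCCC54)c3)ncn2)c1`, 0%

Both compounds were tested in an assay on isolated protein for inhibition of Rho-associated protein kinase 2 (Homo sapiens), read by HTRF, tested at 10 uM; on this read-out higher numbers stand for more inhibition at the one concentration tested (going by the name of the read-out) and lower numbers for less inhibition. In this assay compound 1 gives 0%. Compound 2 gives 0% in this assay, level with compound 1 at the digits reported, and the two values lie within the usual scatter, so nothing separates them.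

Compound 3, `Cc1cccc(N(C)c2cc(Nc3cccc(C(=O)N(CC(C)C)CC(C)C)c3)ncn2)c1`, has not yet been measured. It differs from compound 2 in one place: a group of 9 heavy atoms (8 carbon, 1 nitrogen; no ring) in place of a group of 10 heavy atoms (9 carbon, 1 nitrogen; one six-membered non-aromatic ring of carbon only, one six-membered non-aromatic ring with 1 hetero atom), on a carbonyl carbon. For the measured compounds named here, no pair of measured compounds that differ in one place is available here, so there is no measured step to lean on, and the expectation for compound 3 rests only on where compound 2 stands. Because compound 2 gives 0% and compound 1 gives 0%, no inhibition has been seen at this concentration for either measured compound. The step is therefore expected to be none beyond the scatter, in either direction: a number 3 percentage points higher from compound 2 to compound 3 (within the scatter). Compound 3 is estimated at 3%, with a range from 0% to 20%.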

Compound 3, a percentage reported as inhibition, at one concentration (the size of the read-out at that concentration, not a potency): 0%
Estimate against measurement, compound 3: 3 percentage points above; measured number inside the range.
By their numbers in this assay, from the lowest: compounds 1, 2 and 3 (each within the scatter of the next).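

In this assay there is no change at the digits printed from compound 2 to compound 3 (within the scatter) when diisobutylamino takes the place of the group with two six-membered non-aromatic rings, on a carbonyl carbon whose other neighbour is an aromatic carbon. For the compounds shown here, this is the first comparison here of two compounds that differ in one place, and it shows that swapping this ringed group for one with no ring does not bring any inhibition into view at the single concentration tested. Nothing at hand bears on why the read-out stays where it is.

With no inhibition seen on either side of this change, the pair cannot show whether the group on this carbonyl carbon matters for inhibition at all. As far as these compounds go, it remains open whether a smaller amine such as dimethylamino, a piperazine ring, or a carboxylic acid in place of the amide would give a reading that can be told apart from that of compound 2.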